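Plasma stability of three diesters, with a fourth expected

The source may report more compounds than this note shows. Statements on the series, on what has been measured and on what is new or still open speak of the compounds shown alone.

In an ADME assay on a cell-free system (plasma, Homo sapiens) for metabolic stability, with Plasma (Rattus norvegicus) as the target, read by HPLC, at pH 7.4 (a higher number here means that the compound lasts longer, a lower number that the compound disappears faster), the measured compounds read as follows:
compound 1, `CC(=O)Oc1ccccc1C(=O)O[C@H]1CO[C@H]2[C@@H]1OC[C@H]2OC(=O)c1ccccc1C`: 0.035 h
compound 2, `COc1ccc(C(=O)O[C@@H]2CO[C@H]3[C@@H]2OC[C@@H]3OC(=O)c2ccccc2OC(C)=O)cc1`: 0.0525 h
compound 3, `CC(=O)Oc1ccccc1C(=O)O[C@H]1CO[C@H]2[C@@H]1OC[C@H]2OC(=O)c1ccc([N+](=O)[O-])cc1`: 0.0462 h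

Compound 3 stands second highest of the three half-lives, and both neighbours sit within the scatter of it: a 1.1-fold lower number from compound 2 to compound 3 (0.06 log units; within the scatter) and a 1.3-fold higher number from compound 1 to compound 3 (0.12 log units; within the scatter). Compound 4, `CC(=O)Oc1ccccc1C(=O)O[C@H]1CO[C@H]2[C@@H]1OC[C@H]2OC(=O)c1ccc(CO[N+](=O)[O-])cc1`, differs from compound 3 by (nitrooxy)methyl in place of nitro on an aromatic carbon. Among the measured compounds shown here, the step of a 1.1-fold lower number from compound 2 to compound 3 (0.06 log units; within the scatter) concerns the same place, and a 1.3-fold higher number from compound 1 to compound 3 (0.12 log units; within the scatter) brings the 4-nitrophenyl in; neither introduces a (nitrooxy)methyl, so there is no direct precedent. With every step in the series inside the scatter, no step beyond it is expected in this assay: the expected step is a 1.0-fold lower number from compound 3 to compound 4 (0.00 log units; within the scatter). For compound 4 the estimated half-life is 0.046 h, with a range from 0.02 h to 0.1 h.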

Compound 4, half-life: 0.1 h
Beside the measured number, compound 4's estimate is 2.2-fold (0.34 log units) below it, within the range that was stated.
By their numbers in this assay, from the lowest: compounds 1, 3, 2 and 4 (each within the scatter of the next, the first and the last beyond it).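

In this assay, among the compounds shown here, the aromatic carbon para to a large group now gives a step beyond the scatter, a 2.2-fold higher number from compound 3 to compound 4 (0.34 log units; beyond the scatter), which no earlier pair showed. The change of 4-((nitrooxy)methyl)phenyl for 2-methylphenyl on the carbonyl carbon also passes the scatter, a 2.9-fold higher number from compound 1 to compound 4 (0.46 log units; beyond the scatter), whereas the change from methoxy stays inside it, a 1.9-fold higher number from compound 2 to compound 4 (0.28 log units; within the scatter). Nothing available accounts for these steps. Open, from the compounds shown here alone, is whether an amine or a carboxylic acid at this place would give a similar step. Also open, going by these compounds, is whether a longer chain ending in nitrooxy would do so.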